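Working notes: from compound 2 to compound 4

A few compounds are considered here, and "the series" means these few. Any claim that something is new, unique, unknown or untested is made for them only; others in the source may bear on it.

Measured in an in vitro functional assay on cells for agonist activity at Bombesin receptor subtype-3 (Mus musculus), read by luminescence and calcium flux; a lower number here means that less compound is needed, a higher number that more compound is needed for the effect:
compound 1 `O=C(O)c1ccccc1-c1ccc(CCc2ncc(CC3CCCC3)[nH]2)cc1`: 7.9 nM
compound 2 `O=C(O)c1ccccc1-c1ccc(CCc2ncc(Cc3ccccc3F)[nH]2)cc1`: 9.5 nM
compound 3 `O=C(O)c1ccccc1-c1ccc(CCc2ncc(Cc3ccc(F)cc3)[nH]2)cc1`: 50 nM

Compound 2 has the second highest of the three numbers; its nearest neighbour is compound 1, with a 1.2-fold higher number from compound 1 to compound 2 (0.08 log units; within the scatter), and its furthest is compound 3, with a 5.3-fold higher number from compound 2 to compound 3 (0.72 log units; beyond the scatter).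

Compound 4 `CCC(C)(CC)Cc1cnc(CCc2ccc(-c3ccccc3C(=O)O)cc2)[nH]1` differs from compound 2 by 1-ethyl-1-methylpropyl in place of 2-fluorophenyl on a saturated chain carbon bound to an aromatic carbon. Among the compounds with values here, the only step that bears on it is the exchange of cyclopentyl for 2-fluorophenyl, a 1.2-fold higher number from compound 1 to compound 2 (0.08 log units; within the scatter), read in reverse: a saturated group in that place gives a number close to that of 2-fluorophenyl. The steps to compound 3, a 6.3-fold higher number from compound 1 to compound 3 (0.80 log units; beyond the scatter) and a 5.3-fold higher number from compound 2 to compound 3 (0.72 log units; beyond the scatter), concern 4-fluorophenyl and do not apply. The expected step is therefore a 1.1-fold higher number from compound 2 to compound 4 (0.02 log units; within the scatter), none beyond the scatter. Compound 4 is estimated at 10 nM, range 3 nM to 35 nM.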

Compound 4, half-maximal effective concentration: 30 nM
Compound 4: middle estimate off by 3.0-fold (0.48 log units), on the low side; the measured number falls inside the stated range.
By their numbers in this assay, from the lowest: compounds 1 and 2 (each within the scatter of the next); then compounds 4 and 3 (each within the scatter of the next).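

In this place, on a saturated chain carbon bound to an aromatic carbon, a saturated group does not by itself hold the number: 1-ethyl-1-methylpropyl departs from cyclopentyl (a 3.8-fold higher number from compound 1 to compound 4 (0.58 log units; beyond the scatter)) and from 2-fluorophenyl (a 3.2-fold higher number from compound 2 to compound 4 (0.50 log units; beyond the scatter)). It stands instead within the scatter of 4-fluorophenyl (a 1.7-fold lower number from compound 3 to compound 4 (0.22 log units; within the scatter)). No measurement shown accounts for these steps.

The compounds shown leave open whether the departure follows from the open chain itself or from its branching. Isopropyl or an unbranched pentyl chain in this place would separate the two.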